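The compounds below may be only part of what the source reports. "The series", "measured", "known", "first", "only" and "open" are said of these compounds alone.

The series pairs two aromatic rings through a flexible chain with an ether oxygen at each end; one ring carries an acyl group and a hydroxyl, the other a carboxylic acid. Compound 1 `COc1cc(C(=O)O)ccc1OCCCCOc1ccc(C(=O)CC(C)C)c(O)c1C`, compound 2 `CCC(=O)c1ccc(OCCCCOc2ccc(F)c(C(=O)O)c2)c(C)c1O` and compound 3 `COc1ccc(C(=O)O)cc1OCCCCOc1ccc(C(=O)C(C)C)c(O)c1C` have been measured in an assay on HEK293 cells for positive allosteric modulation of metabotropic glutamate receptor 2 (Rattus norvegicus), read by thallium flux, with a stated time of 2.5 min; a lower number here means a smaller maximal response, a higher number a larger maximal response. In this assay compound 1 gives 85.7%, compound 2 gives 66.6% and compound 3 gives 66.6%. Compound 2 stands level with compound 3 at the digits shown, the two together the lowest of the three numbers, their gap within the usual scatter. Compound 1 returns a number higher than compound 2 by more than the scatter allows.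

Compound 4 `Cc1c(OCCCCOc2ccc(F)c(C(=O)O)c2)ccc(C(=O)C(C)C)c1O` has not been measured. It differs from compound 2 in one place: methyl in place of hydrogen on a saturated chain carbon bound to a carbonyl carbon and a saturated chain carbon; cut one bond further out, the change reads ethyl to isopropyl, or propanoyl to isopropylcarbonyl. For the measured compounds named here, no measured pair isolates this change. Compound 3 already carries the isopropylcarbonyl group and, on a differently substituted acid ring, returns the same number as compound 2. The step in this assay from compound 2 to compound 4 is therefore expected to be small, a number 3.4 percentage points higher from compound 2 to compound 4 (within the scatter), at most a slight rise and not clearly beyond the scatter. Compound 4 is expected to give about 70%, between 55% and 88%.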

Compound 4, largest response reached (reported as percent of maximum), in percent of the reference or control that the assay uses: 74.1%
Compound 4: middle estimate off by 4.1 percentage points, on the low side; the measured number falls inside the stated range.
By their numbers in this assay, from the lowest: compounds 2, 3 and 4 (each within the scatter of the next); then compound 1.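

In this assay, for the compounds shown here, methyl in place of hydrogen on a saturated chain carbon bound to a carbonyl carbon and a saturated chain carbon gives a number 7.5 percentage points higher from compound 2 to compound 4 (within the scatter), the first measured pair that isolates the change from propanoyl to isopropylcarbonyl. The position therefore takes this added methyl without a step beyond the scatter, at least when the rest of the structure is that of compound 2, and this single pair cannot show whether the same holds on a differently substituted acid ring. The data shown offer no measured explanation for the size of this step.

The compounds shown leave open how far this position can be changed before the maximal response moves beyond the scatter, since a cyclopropylcarbonyl or tert-butylcarbonyl group in place of the isopropylcarbonyl group of compound 4 would test a further branched or ring-closed form at the same carbon. They also leave open what a hydroxyl or an amine on this chain, or a longer chain with the rest of compound 4 held fixed, would do to the read-out.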